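Aryl-for-alkylthio exchange on the benzylamide series

A few compounds are considered here, and "the series" means these few. Any claim that something is new, unique, unknown or untested is made for them only; others in the source may bear on it.

Two compounds share the core of compound 1 `CC(C(=O)NCc1ccc(C(F)(F)F)cc1N1CCN(C2CCCCC2)CC1)c1ccc(NS(C)(=O)=O)c(F)c1`. Going by the values given here, in an assay on CHO cells for antagonist activity at transient receptor potential cation channel subfamily V member 1 (Homo sapiens), read by FLIPR (a lower number here means a stronger inhibitor, a higher number a weaker inhibitor), compound 1 gives 13.8 nM, while compound 2 `CCCCSc1cc(C(F)(F)F)ccc1CNC(=O)C(C)c1ccc(NS(C)(=O)=O)c(F)c1` gives 1.9 nM, the lowest of the two numbers; the single step so far, a 7.3-fold lower number from compound 1 to compound 2 (0.86 log units; beyond the scatter), shows that changes at this position move the result beyond the scatter. Compound 3 `COc1ccc(-c2cc(C(F)(F)F)ccc2CNC(=O)C(C)c2ccc(NS(C)(=O)=O)c(F)c2)cc1OC` carries 3,4-dimethoxyphenyl in place of butylsulfanyl on an aromatic carbon. Among the compounds with values here, no measured step exchanges a chain for a ring here, so the direction is uncertain; a modest rise is expected, a 3.2-fold higher number from compound 2 to compound 3 (0.50 log units; beyond the scatter). Compound 3 is therefore expected near 6 nM, within 1.5 nM to 25 nM.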

Compound 3, inhibition constant: 8.6 nM
The estimate for compound 3 lay 1.4-fold (0.16 log units) below the measured number; measured number inside the range.
By their numbers in this assay, from the lowest: compound 2; then compounds 3 and 1 (each within the scatter of the next).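

In this assay the change from butylsulfanyl to 3,4-dimethoxyphenyl gives a 4.5-fold higher number from compound 2 to compound 3 (0.66 log units; beyond the scatter) and so puts a six-membered aromatic ring at this position on the weaker side of the chain. The exchange of 4-cyclohexylpiperazin-1-yl for 3,4-dimethoxyphenyl gives a 1.6-fold lower number from compound 1 to compound 3 (0.21 log units; within the scatter) and leaves these two groups unresolved in this assay. No supporting data bear on the reason for either step.

On these data alone, it remains open whether an unsubstituted phenyl ring would narrow the gap to butylsulfanyl. A pentyl chain or an ethylsulfanyl group would test the role of the sulfur and of chain length.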